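This account rests on a few compounds, and the source may have more. Where it says the series, first, only, none or still open, it means among the compounds named here.

For the measured compounds named here, compound 3 `COc1ccc(O)c(C(=O)Nc2ncc([N+](=O)[O-])s2)c1` stands at the top of the three numbers so far: in an ADME assay on HEK-293T cells (Homo sapiens) for cytotoxicity, read by MTT assay, tested at 25 uM (a higher number here means a weaker effect of the compound at the concentration tested, a lower number a stronger effect), compound 3 gives 100%, level with compound 1 `O=C(Nc1ncc([N+](=O)[O-])s1)c1cc(Cl)ccc1O`, which gives 100%, so that the step of no change at the digits printed from compound 1 to compound 3 (within the scatter) is nothing. Going by the values given here, compound 2 `CC(=O)Oc1ccc(Cl)cc1C(=O)Nc1ncc([N+](=O)[O-])s1` gives 59.5%, and the step of a number 40.5 percentage points lower from compound 1 to compound 2 (beyond the scatter) is the one large change seen. Compound 4 `COc1ccc(OC(C)=O)c(C(=O)Nc2ncc([N+](=O)[O-])s2)c1` differs from compound 3 by acetyl in place of hydrogen on an oxygen on an aromatic ring, the very change that separates compound 1 from compound 2. Because a number 40.5 percentage points lower from compound 1 to compound 2 (beyond the scatter) was large, a drop of similar size is expected for compound 4, namely a number 40 percentage points lower from compound 3 to compound 4 (beyond the scatter). Compound 4 is therefore estimated at 60%, with a range from 40% to 85%.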

Compound 4, a percentage reported as activity, at one concentration (the size of the read-out at that concentration, not a potency): 100%
Estimate against measurement, compound 4: 40 percentage points below; the whole stated range lies below it.
By their numbers in this assay, from the lowest: compound 2; then compounds 1, 3 and 4 (each within the scatter of the next).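

In this assay, acetyl in place of hydrogen on the oxygen gives no change at the digits printed from compound 3 to compound 4 (within the scatter), so this change does not lower the number on every core: the same change on two cores in this assay, a number 40.5 percentage points lower (beyond the scatter) from compound 1 to compound 2 and no change at the digits printed (within the scatter) from compound 3 to compound 4, 40.5 percentage points apart, beyond the scatter of two such steps

Methoxy in place of chloro, which made no difference among the hydroxy compounds, now gives a number 40.5 percentage points higher from compound 2 to compound 4 (beyond the scatter): the same change on two cores in this assay, no change at the digits printed (within the scatter) from compound 1 to compound 3 and a number 40.5 percentage points higher (beyond the scatter) from compound 2 to compound 4, 40.5 percentage points apart, beyond the scatter of two such steps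

Of the four compounds, only compound 2, which joins acetoxy with chloro, stands apart.

Whether this is particular to chloro remains open, with only chloro and methoxy shown on that aromatic carbon. Going by these compounds, what bromo or an amine there would give, or a longer acyl chain in place of acetyl on the oxygen, also stays open.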